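The compounds below may be only part of what the source reports. "The series", "measured", "known", "first", "only" and "open" are said of these compounds alone.

Compound 1 `C=C1CC[C@H]2[C@@](C)(CC[C@@H](OC(=O)c3cccnc3)[C@@]2(C)NC=O)[C@@H]1/C=C/C1=CCOC1=O`: > 50000 nM (a limit)
Compound 2 `C=C1CC[C@H]2[C@@](C)(CC[C@@H](OC(=O)c3ccccc3)[C@@]2(C)NC=O)[C@@H]1/C=C/C1=CCOC1=O`: 50000 nM
Compound 3 `C=C1CC[C@H]2[C@@](C)(CC[C@@H](OC(=O)[C@H](N)CC(C)C)[C@@]2(C)NC=O)[C@@H]1/C=C/C1=CCOC1=O`: > 50000 nM (a limit)

In a functional assay on RAW264.7 cells (Mus musculus) for inhibition, read by Griess assay, with stated times of 3 h and 24 h (a higher number here means a weaker inhibitor, a lower number a stronger inhibitor), compound 3 gives > 50000 nM as a limit, not a number. Compound 4 `C=C1CC[C@H]2[C@@](C)(CC[C@@H](OC(=O)CNC)[C@@]2(C)NC=O)[C@@H]1/C=C/C1=CCOC1=O` alters one place of compound 3: (methylamino)methyl in place of 1-amino-3-methylbutyl on a carbonyl carbon in words, (methylamino)methyl in place of 1-amino-3-methylbutyl on a carbonyl carbon. Going by the values given here, three measured steps concern that carbon: a number no higher from compound 1 to compound 2 (the limit leaves the size open) and a number no lower from compound 2 to compound 3 (the limit leaves the size open) and a step that the two limits leave unreadable from compound 1 to compound 3 all leave their size open. Only compound 2 gives a number, 50000 nM and not a limit. Most of the series sits at the limit of > 50000 nM in this assay, at which 2 of the 3 values shown sit, so no readable step size can be carried over. The expected step is a number no higher from compound 3 to compound 4 (the limit leaves the size open) and none beyond the scatter is expected in this assay here. Compound 4 is estimated at 50000 nM with 25000 nM to 100000 nM as the expected range.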

Compound 4, half-maximal inhibitory concentration: > 50000 nM
Compound 4: no number, only a limit (the forecaster's own chance of this, stated with the estimate: 75%); the middle value lies on the limit itself.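

In this assay, shortening the chain on the carbonyl carbon to (methylamino)methyl and losing the defined stereocentre of 1-amino-3-methylbutyl brought no number into view. Compound 4 joins compound 1 and compound 3 in giving only a limit, so the steps from those two compounds to compound 4 cannot be read, and the position now holds one more group with no measurable size of effect: the limit of > 50000 nM in this assay, at which 3 of the 4 values shown sit.

On these data alone, the remaining step reads a number no lower from compound 2 to compound 4 (the limit leaves the size open), so whether any group on this carbonyl carbon can give a clearly lower number stays open. A carboxylic acid or a dimethylamino group there might settle that.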